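Fluoro in place of iodo on an aromatic carbon

A few compounds are considered here, and "the series" means these few. Any claim that something is new, unique, unknown or untested is made for them only; others in the source may bear on it.

In a functional assay on U-87MG ATCC cells (Homo sapiens) for cytotoxicity, read by MTT assay, with a stated time of 48 h (on this read-out lower numbers stand for stronger inhibition and higher numbers for weaker inhibition), compound 1 (`C/C(=N\NC(=S)Nc1cccc(F)c1)c1ccccn1`) gives 18 nM as its reading. Compound 2 (`C/C(=N/NC(=S)Nc1cccc(I)c1)c1ccccn1`) reads 84 nM on the same scale, which is the higher of the two numbers and lies beyond the scatter from compound 1. Compound 3 (`C/C(=N/NC(=S)Nc1cccc(F)c1)c1ccccn1`) has not yet been measured. Its structure departs from compound 2 by fluoro in place of iodo on an aromatic carbon in total, that is, fluoro in place of iodo on an aromatic carbon. For the measured compounds named here, no measured pair shows this change on its own, so the estimate rests on little. Going by the values given here, the one guide is that compound 1 at 18 nM sits lower than compound 2, and a move toward lower numbers is therefore expected. An estimated 2.8-fold lower number from compound 2 to compound 3 (0.45 log units; beyond the scatter) in that direction is expected to lie beyond the scatter. Compound 3 is estimated at 30 nM in this assay with 9 nM to 100 nM as the expected range.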

Compound 3, half-maximal inhibitory concentration: 18 nM
Compound 3: middle estimate off by 1.7-fold (0.22 log units), on the high side; measured number inside the range.
By their numbers in this assay, from the lowest: compounds 1 and 3 (each within the scatter of the next); then compound 2.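

In this assay, the exchange of iodo for fluoro can now be read on its own: a 4.7-fold lower number from compound 2 to compound 3 (0.67 log units; beyond the scatter). At this place, on an aromatic carbon meta to a large group, the fluoro compound therefore gives the lower number, by a step beyond the scatter. The drawn configuration of the double bond, by contrast, does not separate the two fluoro compounds, with no change at the digits printed from compound 1 to compound 3 (within the scatter), and this comparison isolates that one feature: the fact that compounds 1 and 3 differ only in the configuration as drawn

The compounds shown leave open how other groups would read at this place, such as a methoxy group, an amine or a carboxylic acid. They also leave open whether the two configurations would still read alike with iodo in place of fluoro.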